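The compounds below may be only part of what the source reports. "The series", "measured", "known", "first", "only" and "open" are said of these compounds alone.

The three measured compounds and their values:

Compound 1, `Clc1ccc(/C=N/c2sc3c(c2-c2nc4ccccc4s2)CCC3)c(Cl)c1`: 345 ug/mL
Compound 2, `Fc1ccc(/C=N/c2sc3c(c2-c2nc4ccccc4s2)CCCC3)cc1`: 277 ug/mL
Compound 3, `COc1cc(/C=N/c2sc3c(c2-c2nc4ccccc4s2)CCCC3)cc(OC)c1OC`: 448 ug/mL

In an ADME assay on HeLa cells (Homo sapiens) for cytotoxicity, read by MTT assay, with a stated time of 72 h (a higher number here means that more compound is tolerated, a lower number that less compound is tolerated), the number for compound 2 is the smallest of the three shown, yet the values of compound 1 and compound 3 both lie within the usual scatter of it, so the three compounds cannot be set in any order on this basis. Among the measured compounds shown here, no pair among them differs in only one place, so no single step between measured compounds can be read off.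

Compound 4, `Oc1ccccc1/C=N/c1sc2c(c1-c1nc3ccccc3s1)CCCC2`, has not yet been measured. It differs from compound 2 as follows: 2-hydroxyphenyl in place of 4-fluorophenyl on a carbon with a double bond to nitrogen. For the measured compounds named here, since nothing among the measured compounds shows how this assay responds to such a change, and since the three numbers available all sit close together, a step no larger than the scatter is expected, in no particular direction. Compound 4 is therefore estimated to give 300 ug/mL in this assay, with a range from 150 ug/mL to 600 ug/mL. The step of a 1.1-fold higher number from compound 2 to compound 4 (0.03 log units; within the scatter) that this estimate implies is expected to stay within the scatter.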

Compound 4, half-maximal cytotoxic concentration: 122 ug/mL
Beside the measured number, compound 4's estimate is 2.5-fold (0.39 log units) above it; measured number outside the range, below it.
By their numbers in this assay, from the lowest: compound 4; then compounds 2, 1 and 3 (each within the scatter of the next).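

In this assay, 2-hydroxyphenyl in place of 4-fluorophenyl on a carbon with a double bond to nitrogen gives a 2.3-fold lower number from compound 2 to compound 4 (0.36 log units; beyond the scatter) and so marks this position as one where a change can be read beyond the scatter, though only modestly. The earlier compounds shown here could not show this, as no pair among them differed in only one place. Nothing available explains the step, so it stands as an observation alone.

From the compounds shown here alone, with this single pair, it stays open whether the step follows from the arrival of the hydroxy group or the departure of the fluorine. The compounds shown also leave open how an amine or a carboxylic acid in the same place would read in this assay, and whether the same change would give a similar step on the core of compound 1.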